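Swapping halogens on the ester-bearing ring of a chromone

The source may hold more compounds than are shown below. What is called first, only, known or untested is meant among the compounds shown, and "the series" means these compounds.

Three compounds share one core and differ only in the substituted phenyl ester attached through an oxygen next to a carbonyl group. In a functional assay on cells (T-cell, Mus musculus, strain BALB/c) for inhibition, read by MTT assay, with a stated time of 72 h (a higher number here means a weaker inhibitor, a lower number a stronger inhibitor), compound 1 `COC(=O)c1cc(F)ccc1OC(=O)COc1cc(O)c2c(=O)cc(-c3ccccc3)oc2c1` gives 6820 nM, compound 2 `COC(=O)c1c(Br)cccc1OC(=O)COc1cc(O)c2c(=O)cc(-c3ccccc3)oc2c1` gives 41700 nM, and compound 3 `COC(=O)c1ccc(Br)cc1OC(=O)COc1cc(O)c2c(=O)cc(-c3ccccc3)oc2c1` gives 17600 nM. Compound 3 stands second highest of the three: a 2.4-fold lower number from compound 2 to compound 3 (0.37 log units; beyond the scatter) and a 2.6-fold higher number from compound 1 to compound 3 (0.41 log units; beyond the scatter).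

Compound 4 `COC(=O)c1c(Cl)cccc1OC(=O)COc1cc(O)c2c(=O)cc(-c3ccccc3)oc2c1` has not yet been tested. Going from compound 3 to compound 4 means (a group of 11 heavy atoms (8 carbon, 2 oxygen, 1 chlorine; one six-membered aromatic ring of carbon only) in place of a group of 11 heavy atoms (8 carbon, 2 oxygen, 1 bromine; one six-membered aromatic ring of carbon only), on an oxygen next to a carbonyl group), so compound 4 differs from compound 2 only in carrying chlorine in place of bromine.

The relevant measured steps are a 2.4-fold lower number from compound 2 to compound 3 (0.37 log units; beyond the scatter) and a 6.1-fold higher number from compound 1 to compound 2 (0.79 log units; beyond the scatter), both modest but beyond the scatter. Reversing the step from compound 2 to compound 3 would give a higher number, while the halogen swap itself is an unknown. For compound 4 the number in this assay is therefore expected to rise, about a 1.6-fold higher number from compound 3 to compound 4 (0.20 log units; within the scatter). Compound 4 is estimated at 28000 nM, with a likely range from 11000 nM to 70000 nM.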

Compound 4, half-maximal inhibitory concentration: 38900 nM
Compound 4: the middle estimate sits 1.4-fold (0.14 log units) below what was measured, within the range that was stated.
By their numbers in this assay, from the lowest: compound 1; then compound 3; then compounds 4 and 2 (each within the scatter of the next).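

Chloro in place of bromo on an aromatic carbon gives a 1.1-fold lower number from compound 2 to compound 4 (0.03 log units; within the scatter) in this assay, and this is the first pair here in which only the halogen changes. Compound 4 also shows a 2.2-fold higher number from compound 3 to compound 4 (0.34 log units; beyond the scatter) and a 5.7-fold higher number from compound 1 to compound 4 (0.76 log units; beyond the scatter), so it keeps the standing of compound 2 relative to the other two compounds. Changing where bromine sits gives a 2.4-fold lower number from compound 2 to compound 3 (0.37 log units; beyond the scatter), beyond the scatter, whereas this swap of one halogen for another stays within it.

Nothing available explains this outcome. As far as these compounds go, whether a methyl group, a methoxy group or an amine on that aromatic carbon would give a similar number remains open, as does the effect of replacing the methyl ester with a carboxylic acid.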